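This account rests on a few compounds, and the source may have more. Where it says the series, first, only, none or still open, it means among the compounds named here.

Measured compounds in a physicochemical assay for solubility, read by fluorescence and spectrophotometry; on this read-out higher numbers stand for higher solubility and lower numbers for lower solubility:
compound 1 `Cc1nc2ccccc2n1CC(=O)N/N=C/c1c(O)ccc2ccccc12`: 20000 nM
compound 2 `Cc1nc2ccccc2n1CCCC(=O)N/N=C/c1c(O)ccc2ccccc12`: 120000 nM
compound 3 `O=C(CCn1c(C(F)(F)F)nc2ccccc21)N/N=C/c1c(O)ccc2ccccc12`: 30000 nM

Compound 3 sits second highest of the three numbers. Its value lies within the usual scatter of compound 1, so no order between those two is claimed; compound 2 gives a higher number than compound 3, and that gap is beyond the scatter.

Compound 4 `O=C(CCn1cnc2ccccc21)N/N=C/c1c(O)ccc2ccccc12` differs from compound 3 by hydrogen in place of trifluoromethyl on an aromatic carbon. Going by the values given here, no step between measured compounds isolates this change, so nothing measured here tells its size. A small rise in this assay is expected, of a size that may not clear the scatter; the expected step is a 1.7-fold higher number from compound 3 to compound 4 (0.22 log units; within the scatter). Compound 4 is expected to give 50000 nM, with a range from 20000 nM to 120000 nM.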

Compound 4, solubility: 30000 nM
Compound 4: the middle estimate sits 1.7-fold (0.22 log units) above what was measured; the measured number falls inside the stated range.
By their numbers in this assay, from the lowest: compounds 1, 3 and 4 (each within the scatter of the next); then compound 2.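

In this assay, going by these compounds alone, hydrogen in place of trifluoromethyl on an aromatic carbon between two ring nitrogen atoms gives no change at the digits printed from compound 3 to compound 4 (within the scatter), the first step that isolates this position. Trifluoromethyl and hydrogen therefore cannot be told apart here on this read-out. No measured evidence bears on why this is so.

Going by these compounds, whether an amine or a carboxylic acid at this position would give a step beyond the scatter remains open. Also open, on these data alone, is whether the same exchange would give a similar step on the chain of compound 2.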